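Compound 3 to compound 4: a swap on the carbonyl

This account rests on a few compounds, and the source may have more. Where it says the series, first, only, none or still open, it means among the compounds named here.

Of the compounds shown here, three on the shared core have been measured: compound 1 (`Cc1ccc(S(=O)(=O)N[C@@H](CC(=O)NC(C)(C)C)C(=O)NCCNC(=O)c2cc(Cl)ccn2)cc1`), compound 2 (`Cc1ccc(S(=O)(=O)N[C@@H](CC(=O)NC(C)(C)C)C(=O)NCCNC(=O)c2ccccc2)cc1`) and compound 3 (`Cc1ccc(S(=O)(=O)N[C@@H](CC(=O)NC(C)(C)C)C(=O)NCCNC(=O)c2ccccc2F)cc1`). In an ADME assay on Karpas-1106P cells (Homo sapiens) for cytotoxicity (on this read-out higher numbers stand for an effect only at larger amounts of compound and lower numbers for an effect already at smaller amounts), compound 1 gives > 11100 nM as a limit. Compound 2 gives > 11100 nM as a limit. Compound 3 gives > 11100 nM as a limit and not a number. For the measured compounds named here, the series so far shows the limit of > 11100 nM in this assay, at which 3 of the 3 values shown sit, and nothing more.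

Compound 4 (`COc1cc(OC)cc(C(=O)NCCNC(=O)[C@H](CC(=O)NC(C)(C)C)NS(=O)(=O)c2ccc(C)cc2)c1`) carries 3,5-dimethoxyphenyl in place of 2-fluorophenyl on a carbonyl carbon. Bearing on this change are a step that the two limits leave unreadable from compound 1 to compound 2 and a step that the two limits leave unreadable from compound 1 to compound 3 and also a step that the two limits leave unreadable from compound 2 to compound 3 as the third case. None of these has a readable size.

Starting from compound 3 at > 11100 nM as a limit, no step beyond the scatter is expected in this assay and another limit is the likely report. The expected step reads a step that the limit leaves unreadable from compound 3 to compound 4 as an estimate only. Compound 4 is estimated at 15000 nM with an expected range of 7000 nM to 32000 nM on this read-out.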

Compound 4, half-maximal effective concentration: > 11100 nM
Compound 4: no number, only a limit; the forecaster's own chance of this, stated with the estimate: 90%; the middle value does not contradict the limit.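

In this assay, for the compounds shown here, compound 4 gives > 11100 nM, a limit and not a number, so no step from compound 1, compound 2 or compound 3 to compound 4 can be read. The compounds shown leave open whether any group on this carbonyl carbon changes the read-out, with the series resting at a single reported limit: the limit of > 11100 nM in this assay, at which 4 of the 4 values shown sit.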